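From 1-cyano-1-methylethyl to 1-cyanocyclobutyl on the amide

The compounds below may be only part of what the source reports. "The series", "measured", "known", "first", "only" and "open" are said of these compounds alone.

Measured so far in a functional assay on A20 cells (Mus musculus) for inhibition, with stated times of 1 h, 16 h and 24 h (a higher number here means a weaker inhibitor, a lower number a stronger inhibitor), as follows
- compound 1 `N#CCNC(=O)[C@@H]1C[C@@H](S(=O)(=O)c2ccccc2Cl)C[C@H]1C(=O)N1CCOCC1` gives 3 nM here
- compound 2 `CC(C)(C#N)NC(=O)[C@@H]1C[C@@H](S(=O)(=O)c2ccccc2)C[C@H]1C(=O)N1CCOCC1` gives 43 nM here

Compound 2 at 43 nM holds the higher of the two numbers, beyond the scatter from compound 1. Among the compounds with values here, compound 3 `N#CC1(NC(=O)[C@@H]2C[C@@H](S(=O)(=O)c3ccccc3)C[C@H]2C(=O)N2CCOCC2)CCC1` has 1-cyanocyclobutyl in place of 1-cyano-1-methylethyl on an amide-type nitrogen as its only change. Within the data shown here, no measured pair shows this kind of change, so no step beyond the scatter is expected in this assay and no direction is favoured. The expected change is a 1.1-fold lower number from compound 2 to compound 3 (0.03 log units; within the scatter) in size. For compound 3 the estimate is 40 nM with an expected range from 12 nM to 130 nM for now.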

Compound 3, half-maximal inhibitory concentration: 236 nM
Compound 3: the middle estimate sits 5.9-fold (0.77 log units) below what was measured; the measured number lies above the stated range.
By their numbers in this assay, from the lowest: compound 1; then compound 2; then compound 3.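

In this assay, within the data shown here, 1-cyanocyclobutyl in place of 1-cyano-1-methylethyl on the amide-type nitrogen gives a 5.5-fold higher number from compound 2 to compound 3 (0.74 log units; beyond the scatter) as the first single-change reading at this position. This position is therefore sensitive to the change, and the larger ring-containing group gives the weaker inhibitor in this pair. No measured evidence bears on the origin of this step.

Open, as far as these compounds go, is how 1-cyanocyclopropyl or 1-cyanocyclopentyl on the same nitrogen would compare with compound 3. Also open, from the compounds shown here alone, is whether the same change gives a similar step on the core of compound 1.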